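From 3,5-dimethoxyphenyl to 4-hydroxyphenyl: estimate for compound 3

The compounds below may be only part of what the source reports. "The series", "measured", "known", "first", "only" and "open" are said of these compounds alone.

In a functional assay on MCF7 cells (Homo sapiens) for inhibition, read by fluorescence, with a stated time of 72 h (on this read-out lower numbers stand for stronger inhibition of growth and higher numbers for weaker inhibition of growth), compound 1 `CCCCCCn1cnc2c(Nc3ccc(Cl)cc3)nc(N[C@H]3CC[C@H](N)CC3)nc21` gives 4200 nM, and compound 2 `CCCCCCn1cnc2c(Nc3cc(OC)cc(OC)c3)nc(N[C@H]3CC[C@H](N)CC3)nc21` gives 3500 nM, so the two stand level within the scatter. Compound 3 `CCCCCCn1cnc2c(Nc3ccc(O)cc3)nc(N[C@H]3CC[C@H](N)CC3)nc21` carries 4-hydroxyphenyl in place of 3,5-dimethoxyphenyl on a nitrogen on an aromatic ring. Among the measured compounds shown here, the only measured step at this place, a 1.2-fold lower number from compound 1 to compound 2 (0.08 log units; within the scatter), exchanged 4-chlorophenyl for 3,5-dimethoxyphenyl and stayed within the scatter. For the measured compounds named here, no measured compound yet carries 4-hydroxyphenyl, so nothing beyond the scatter is expected in this assay. The expected step is a 1.1-fold higher number from compound 2 to compound 3 (0.06 log units; within the scatter). Compound 3 is estimated at 4000 nM, with an expected range of 1500 nM to 10000 nM.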

Compound 3, concentration for 50% growth inhibition: 3500 nM
Compound 3: middle estimate off by 1.1-fold (0.06 log units), on the high side, within the range that was stated.
By their numbers in this assay, from the lowest: compounds 2, 3 and 1 (each within the scatter of the next).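

In this assay, among the compounds shown here, the step to the first compound with a hydrogen-bond donor on this aryl group stays within the scatter (no change at the digits printed from compound 2 to compound 3 (within the scatter)), so 4-hydroxyphenyl stands level with 3,5-dimethoxyphenyl. Hydroxy in place of chloro on an aromatic carbon also stays within the scatter (a 1.2-fold lower number from compound 1 to compound 3 (0.08 log units; within the scatter)), so all three aryl groups on this nitrogen now stand level. No evidence on hand accounts for this flat result. Still open, going by these compounds, is whether an amine or a carboxylic acid on this aromatic ring would move the number beyond the scatter.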